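The compounds below may be only part of what the source reports. "The series", "measured", "known", "first", "only" and "open" are said of these compounds alone.

Two compounds measured in a functional assay on CHO-K1 cells for agonist activity at Glucose-dependent insulinotropic receptor (Homo sapiens), read by a luciferase reporter, with a stated time of 5 h (on this read-out lower numbers stand for an effect already at smaller amounts and higher numbers for an effect only at larger amounts of compound), give the starting point. Compound 1 `CC(C)(C)OC(=O)N1CCC(Oc2cccc3c2ccn3-c2ccc(S(C)(=O)=O)cc2)CC1` gives 631 nM there. Compound 2 `CS(=O)(=O)c1ccc(N2CCc3c(OC4CCN(C(=O)OCCF)CC4)ncnc32)c(F)c1` gives 501 nM in this assay, a number that falls within the usual scatter of the figure for compound 1, so the two cannot be told apart. Compound 3 `CS(=O)(=O)c1ccc(N2CCc3c(OC4CCN(C5=NCCCN5)CC4)ncnc32)c(F)c1` has not yet been measured in this assay; it differs from compound 2 in one place: a group of 6 heavy atoms (4 carbon, 2 nitrogen; one six-membered non-aromatic ring with 2 hetero atoms) in place of a group of 6 heavy atoms (3 carbon, 2 oxygen, 1 fluorine; no ring), on an amine nitrogen in a ring. Within the data shown here, no measured pair shows a change of this kind, so the expected step is only a guess. Compound 3 is expected to give about 800 nM in this assay, between 200 nM and 4000 nM, an estimated step of a 1.6-fold higher number from compound 2 to compound 3 (0.20 log units; within the scatter) that is not far beyond the scatter.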

Compound 3, half-maximal effective concentration: 2000 nM
Compound 3: middle estimate off by 2.5-fold (0.40 log units), on the low side; low and high end bracket the measured number.
By their numbers in this assay, from the lowest: compounds 2 and 1 (each within the scatter of the next); then compound 3.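

In this assay, putting the six-membered non-aromatic ring with 2 hetero atoms on the amine nitrogen in place of (2-fluoroethoxy)carbonyl gives a 4.0-fold higher number from compound 2 to compound 3 (0.60 log units; beyond the scatter). This position is therefore sensitive to what it carries, even when the heavy-atom count stays the same and the entering group adds a hydrogen-bond donor. Nothing measured here explains the rise. An open-chain guanidine on the same nitrogen could help separate the contribution of the ring from that of its nitrogen atoms, while a small alkyl group would test whether any carbonyl-bearing or nitrogen-rich group is needed.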